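Urea to amide on the aryl-pyrazole series

A few compounds are considered here, and "the series" means these few. Any claim that something is new, unique, unknown or untested is made for them only; others in the source may bear on it.

Of the compounds shown here, two have been measured. Compound 1 `COc1cc(Cl)cc(-c2nn(-c3cccc(NC(=O)Nc4ccc(Cl)c(Cl)c4)c3)cc2-c2ccncc2)c1` gives 1480 nM in a functional assay on A549 cells (Homo sapiens) for inhibition, read by sulforhodamine B assay, with a stated time of 48 h; a lower number here means a stronger inhibitor, a higher number a weaker inhibitor. Compound 2 `COc1cc(Cl)cc(-c2nn(-c3cccc(NC(=O)Nc4cccc(C(F)(F)F)c4)c3)cc2-c2ccncc2)c1` gives 730 nM in this assay. Going by the values given here, the only step between them, a 2.0-fold lower number from compound 1 to compound 2 (0.31 log units; beyond the scatter), leaves compound 2 with the lower of the two numbers, compound 1 with the higher.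

Compound 3 `COc1cc(Cl)cc(-c2nn(-c3cccc(NC(=O)c4cccc(C(F)(F)F)c4)c3)cc2-c2ccncc2)c1` is not yet measured. It differs from compound 2 by 3-(trifluoromethyl)phenyl in place of (3-(trifluoromethyl)phenyl)amino on a carbonyl carbon: the (3-(trifluoromethyl)phenyl)amino that sits on the carbonyl carbon leaves, and 3-(trifluoromethyl)phenyl enters in its place, so one hydrogen-bond donor is lost. Among the compounds with values here, the one measured step, from compound 1 to compound 2, exchanges the aryl on the amide-type nitrogen and does not touch the carbonyl carbon; it gives no direct guide to this change, and no other pair does. A change of this kind is therefore a guess: the expectation is a modest rise in the number, a 2.1-fold higher number from compound 2 to compound 3 (0.31 log units; beyond the scatter), with a wide margin. Compound 3 is estimated at 1500 nM in this assay, between 400 nM and 6000 nM.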

Compound 3, half-maximal inhibitory concentration: 3620 nM
Beside the measured number, compound 3's estimate is 2.4-fold (0.38 log units) below it, within the range that was stated.
By their numbers in this assay, from the lowest: compound 2; then compound 1; then compound 3.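

Going by these compounds alone, putting 3-(trifluoromethyl)phenyl in place of (3-(trifluoromethyl)phenyl)amino on the carbonyl carbon is the first change at this place, and in this assay it gives a 5.0-fold higher number from compound 2 to compound 3 (0.70 log units; beyond the scatter) with one hydrogen-bond donor gone. The amide also stands above the other urea (a 2.4-fold higher number from compound 1 to compound 3 (0.39 log units; beyond the scatter)), so among these three compounds both ureas hold lower numbers than the amide, whichever aryl group the urea carries. No measurement at hand bears on why the number rises.

On these data alone, whether the rise follows the lost hydrogen-bond donor or the lost linking atom stays open: a methylene group in place of the amino nitrogen, or a methylamino link, would separate the two. Also open, as far as these compounds go, is whether the 3,4-dichlorophenyl group on the same amide would follow the 3-(trifluoromethyl)phenyl group.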